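Swapping Fluoro for Hydroxy on the Outer Aryl Ring

A few compounds are considered here, and "the series" means these few. Any claim that something is new, unique, unknown or untested is made for them only; others in the source may bear on it.

Compound 1, `COc1cc(-c2nccn3cc(-c4ccc(N)cc4)nc23)cc(OC)c1OC`: 287 nM
Compound 2, `COc1cc(-c2nccn3cc(-c4ccc(F)cc4)nc23)cc(OC)c1OC`: 137 nM
Compound 3, `COc1cc(-c2nccn3cc(-c4ccccc4)nc23)cc(OC)c1OC`: 378 nM

Three compounds on one shared core were tested in a functional assay on A549 cells (Homo sapiens) for inhibition, read by MTT assay, with a stated time of 48 h; a lower number here means a stronger inhibitor, a higher number a weaker inhibitor. Compound 2 holds the lowest number of the three, with compound 1 nearest and compound 3 furthest. Compound 4, `COc1cc(-c2nccn3cc(-c4ccc(O)cc4)nc23)cc(OC)c1OC`, differs from compound 2 by hydroxy in place of fluoro on an aromatic carbon. Within the data shown here, two measured steps bear on this: a 2.1-fold lower number from compound 1 to compound 2 (0.32 log units; beyond the scatter) and a 2.8-fold higher number from compound 2 to compound 3 (0.44 log units; beyond the scatter). Both show fluoro giving a modestly lower number than either amino or hydrogen, while a 1.3-fold higher number from compound 1 to compound 3 (0.12 log units; within the scatter). Hydroxy, like amino, brings one hydrogen-bond donor and one acceptor. Because compound 1 gives 287 nM, compound 4 is expected to show a modest rise, a 2.2-fold higher number from compound 2 to compound 4 (0.34 log units; beyond the scatter). Compound 4 is estimated at 300 nM, within 120 nM to 750 nM.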

Compound 4, half-maximal inhibitory concentration: > 10000 nM
Compound 4 gave a limit, no number; the forecaster's own chance of this, stated with the estimate: 3%; middle value at least 33-fold (1.52 log units) away from the limit.
By their numbers in this assay, from the lowest: compound 2; then compounds 1 and 3 (each within the scatter of the next). At a limit, above all of these: compound 4.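

Compound 4 gives a limit in this assay, not a number: the limit of > 10000 nM in this assay, at which 1 of the 4 values shown sits. The earlier swaps at this position gave only modest steps or steps within the scatter, whereas hydroxy stands far from all three other groups, with an at least 72-fold higher number from compound 2 to compound 4 (1.86 log units; beyond the scatter), an at least 34-fold higher number from compound 1 to compound 4 (1.54 log units; beyond the scatter) and an at least 26-fold higher number from compound 3 to compound 4 (1.42 log units; beyond the scatter). So this position is much less forgiving than the earlier compounds suggested, and one small swap on the outer ring can matter greatly.

Why hydroxy differs so sharply stays open. The compounds shown also cannot say how methoxy, chloro or a carboxylic acid would fare here.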